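Shortening the hydroxyalkyl chain: from compound 1 to compound 4

This account rests on a few compounds, and the source may have more. Where it says the series, first, only, none or still open, it means among the compounds named here.

Measured so far in a functional assay on cells (Neutrophil, Homo sapiens) for inhibition, with a stated time of 10 min; a higher number here means a weaker inhibitor, a lower number a stronger inhibitor:
compound 1, `CCOC(=O)c1cnn(CC(O)CC)c1NC(=O)NC(C)C`: > 10 nM
compound 2, `CCOC(=O)c1cnn(CC(O)CC)c1NC(=O)NCc1ccccc1`: > 10 nM
compound 3, `CCOC(=O)c1cnn(CC(C)O)c1NC(=O)Nc1cccc2ccccc12`: 9.8 nM

Compound 1 stands only at a limit of this assay, not at a number. The same holds for compound 2. Among the measured compounds shown here, compound 3 is the one member with a number in this assay. For the measured compounds named here, the single measured step, a step that the two limits leave unreadable from compound 1 to compound 2, cannot be read, because both of its ends sit at the limit (the limit of > 10 nM in this assay, at which 2 of the 3 values shown sit).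

Compound 4, `CCOC(=O)c1cnn(CC(C)O)c1NC(=O)NC(C)C`, differs from compound 1 by hydrogen in place of methyl on a saturated chain carbon, two bonds along the chain from an oxygen on a saturated carbon. Going by the values given here, no measured step touches this chain, so none bears directly on the change. Compound 3 carries the same 2-hydroxypropyl chain and gives a number, but it also differs from compound 1 in the group on the urea nitrogen, so its value cannot be assigned to the chain alone.

With no readable step to lean on, compound 4 is expected to stay close to compound 1, the step that the limit leaves unreadable from compound 1 to compound 4 being estimated as none beyond the scatter. The estimate for compound 4 is 25 nM, with a range from 8 nM to 80 nM, and most likely it is again reported only as a limit.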

Compound 4, half-maximal inhibitory concentration: 90 nM
For compound 4 the middle estimate is 3.6-fold (0.56 log units) below the measured one; the measured number lies above the stated range.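

No new step can be read between compound 1 and compound 4, as compound 1 stands only at a limit: the limit of > 10 nM in this assay, at which 2 of the 4 values shown sit.

Whether 2-hydroxypropyl in place of 2-hydroxybutyl changes inhibition, and by how much, stays open, as no pair of compounds shown differing only in this chain has numbers at both ends.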